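Cytotoxicity in HepG2 Cells Across Three Quinoline Analogues

This account rests on a few compounds, and the source may have more. Where it says the series, first, only, none or still open, it means among the compounds named here.

Measured compounds:
Compound 1, `Cc1cc(C)cc(Cc2ccc3c(NCCCNCc4ccco4)ccnc3c2)c1`: 6270 nM
Compound 2, `COc1cccc(CNCCCNc2ccnc3cc(Cc4cc(C)cc(C)c4)ccc23)c1O`: 2680 nM
Compound 3, `COc1cccc(Oc2ccc3c(NCCCNCc4ccco4)ccnc3c2)c1`: 15500 nM

The three compounds were tested in an ADME assay on HepG2 cells (Homo sapiens) for cytotoxicity, read by luminescence, CellTiter-Glo and ATP content, with a stated time of 72 h; on this read-out lower numbers stand for an effect already at smaller amounts and higher numbers for an effect only at larger amounts of compound. Compound 1 gives 6270 nM, compound 2 gives 2680 nM and compound 3 gives 15500 nM, the highest of the three numbers.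

Two changes connect them. The change 2-hydroxy-3-methoxyphenyl in place of furan-2-yl on a saturated chain carbon bound to an amine nitrogen gives a 2.3-fold lower number from compound 1 to compound 2 (0.37 log units; beyond the scatter). The change 3-methoxyphenoxy in place of 3,5-dimethylbenzyl on an aromatic carbon gives a 2.5-fold higher number from compound 1 to compound 3 (0.39 log units; beyond the scatter).

Compound 4, `COc1cccc(Oc2ccc3c(NCCCNCc4cccc(OC)c4O)ccnc3c2)c1`, has not yet been measured in this assay. It differs from compound 3 by 2-hydroxy-3-methoxyphenyl in place of furan-2-yl on a saturated chain carbon bound to an amine nitrogen, the same kind of change as that from compound 1 to compound 2, made here on the core of compound 3 rather than on the core of compound 1; the two cores differ by 3-methoxyphenoxy in place of 3,5-dimethylbenzyl on an aromatic carbon. The expectation is that the step from compound 3 to compound 4 will be a 2.3-fold lower number from compound 3 to compound 4 (0.36 log units; beyond the scatter), resting on the earlier step of a 2.3-fold lower number from compound 1 to compound 2 (0.37 log units; beyond the scatter). Compound 4 is therefore estimated at 6700 nM, between 3000 nM and 15000 nM.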

Compound 4, half-maximal effective concentration in the HepG2 assay: 5300 nM
For compound 4 the middle estimate is 1.3-fold (0.10 log units) above the measured one; low and high end bracket the measured number.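

For the compounds shown here, in the HepG2 assay compound 4 gives 5300 nM, and 2-hydroxy-3-methoxyphenyl in place of furan-2-yl gives a 2.9-fold lower number from compound 3 to compound 4 (0.47 log units; beyond the scatter), so this change carries over from the core of compound 1 to the core of compound 3 in direction and, within the scatter, in size: the same change on two cores in the HepG2 assay, a 2.3-fold lower number (0.37 log units; beyond the scatter) from compound 1 to compound 2 and a 2.9-fold lower number (0.47 log units; beyond the scatter) from compound 3 to compound 4, 1.3-fold (0.10 log units) apart, within the scatter of two such steps In the HepG2 assay, the other change, 3-methoxyphenoxy in place of 3,5-dimethylbenzyl, gives a 2.0-fold higher number from compound 2 to compound 4 (0.30 log units; within the scatter), and this step also agrees with its earlier counterpart: the same change on two cores in the HepG2 assay, a 2.5-fold higher number (0.39 log units; beyond the scatter) from compound 1 to compound 3 and a 2.0-fold higher number (0.30 log units; within the scatter) from compound 2 to compound 4, 1.3-fold (0.10 log units) apart, within the scatter of two such steps This agreement rests on only two cores and does not show that the change would behave alike on others. In a physicochemical assay for solubility, with a stated time of 18 h, at pH 7.4 (on this read-out lower numbers stand for lower solubility and higher numbers for higher solubility), compound 3 gives 14500 nM and compound 4 gives 14500 nM. Going by these compounds alone, in the physicochemical assay the single step, no change at the digits printed from compound 3 to compound 4 (within the scatter), stands on one core and says nothing about carrying the change over.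

The compounds shown leave open whether the hydroxyl or the methoxy of the 2-hydroxy-3-methoxyphenyl group accounts for the step, which a plain phenyl or a 2-hydroxyphenyl on the same carbon could help to settle. From the compounds shown here alone, it also remains open how the step would read with a thiophen-2-yl group or on a core with a longer chain.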